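The compounds below may be only part of what the source reports. "The series", "measured", "known", "first", "only" and "open" are said of these compounds alone.

Values so far in a functional assay on HL-60 cells (Homo sapiens) for cytotoxicity, read by WST assay, with a stated time of 48 h; on this read-out lower numbers stand for an effect already at smaller amounts and higher numbers for an effect only at larger amounts of compound:
- compound 1 `CCCCOc1cccc(C[C@H]2C(=O)OC[C@@H]2Cc2ccccc2)c1` gives 26000 nM
- compound 2 `CCCCCCCOc1cccc(C[C@H]2C(=O)OC[C@@H]2Cc2ccccc2)c1` gives 81000 nM
- compound 3 `O=C1OC[C@H](Cc2ccccc2)[C@H]1Cc1ccc(O)cc1` gives 88000 nM

Compound 3 at 88000 nM sits level with compound 2 within the scatter, while compound 1 shows the lower number, beyond the scatter. Compound 4 `O=C1OC[C@H](Cc2ccccc2)[C@H]1Cc1ccc(F)cc1` carries fluoro in place of hydroxy on an aromatic carbon para to a large group. For the measured compounds named here, the only measured step of a 3.1-fold higher number from compound 1 to compound 2 (0.49 log units; beyond the scatter) is modest and lies on a saturated chain, not at this carbon, so it bears only loosely on the change. In this assay little movement is therefore expected, with no firm direction. The estimated step of a 1.3-fold lower number from compound 3 to compound 4 (0.10 log units; within the scatter) stays within the scatter. For compound 4 the estimate is 70000 nM with an expected range from 25000 nM to 200000 nM around it.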

Compound 4, half-maximal effective concentration: 57000 nM
Compound 4: the middle estimate sits 1.2-fold (0.09 log units) above what was measured; the range from low to high includes it.
By their numbers in this assay, from the lowest: compound 1; then compounds 4, 2 and 3 (each within the scatter of the next).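

Putting fluoro in place of hydroxy on this aromatic carbon, para to a large group, gives a step that stays within the scatter in this assay (a 1.5-fold lower number from compound 3 to compound 4 (0.19 log units; within the scatter)). Compounds 3 and 4 thus read alike, although the hydrogen-bond donor and acceptor counted for hydroxy are absent from fluoro. For the compounds shown here, this is the first step at this aromatic carbon rather than on a saturated chain. No measurement at hand explains this result.

The compounds shown leave open whether an amine, a carboxylic acid or a methoxy group on this carbon would move the number beyond the scatter.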